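Notes on the amine substituent series at the shared core

The source may report more compounds than this note shows. Statements on the series, on what has been measured and on what is new or still open speak of the compounds shown alone.

Measured so far in a functional assay on isolated protein for agonist activity at Glucose-dependent insulinotropic receptor (Homo sapiens), read by HTRF and cAMP accumulation; a higher number here means that more compound is needed for the effect, a lower number that less compound is needed:
- compound 1 `CC(C)(C)OC(=O)N1CCC(O[C@H]2CC[C@H](Oc3cnc(S(C)(=O)=O)cn3)CC2)CC1` gives 5.9 nM
- compound 2 `CC(C)OC(=O)N1CCC(O[C@H]2CC[C@H](Oc3cnc(S(C)(=O)=O)cn3)CC2)CC1` gives 13.7 nM
- compound 3 `CS(=O)(=O)c1cnc(O[C@H]2CC[C@H](OC3CCN(C(=O)C4(C(F)(F)F)CCCC4)CC3)CC2)cn1` gives 38.4 nM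

Compound 3 gives the highest number of the three. The two steps that reach it, a 6.5-fold higher number from compound 1 to compound 3 (0.81 log units; beyond the scatter) and a 2.8-fold higher number from compound 2 to compound 3 (0.45 log units; beyond the scatter), both exchange the group on the carbonyl carbon and both lie beyond the scatter, as does a 2.3-fold higher number from compound 1 to compound 2 (0.37 log units; beyond the scatter).

Compound 4 `CS(=O)(=O)c1cnc(O[C@H]2CC[C@H](OC3CCN(CC4(C(F)(F)F)CC4)CC3)CC2)cn1` is not yet measured. It differs from compound 3 in one place: a group of 8 heavy atoms (5 carbon, 3 fluorine; one three-membered non-aromatic ring of carbon only) in place of a group of 11 heavy atoms (7 carbon, 1 oxygen, 3 fluorine; one five-membered non-aromatic ring of carbon only), on an amine nitrogen in a ring. Within the data shown here, the carbonyl itself is thus removed, and no measured step in this set touches that part; the three known steps all keep the carbonyl and vary only what sits on it. They therefore bear on the change from compound 3 to compound 4 only loosely, and they show that variations around this nitrogen move the number by modest amounts. A step of modest size in either direction, or none beyond the scatter, is the most that can be read from them.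

Compound 4 is expected to give about 50 nM, within 10 nM to 250 nM, which means an estimated step of a 1.3-fold higher number from compound 3 to compound 4 (0.11 log units; within the scatter).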

Compound 4, half-maximal effective concentration: 62.6 nM
For compound 4 the middle estimate is 1.3-fold (0.10 log units) below the measured one; low and high end bracket the measured number.
By their numbers in this assay, from the lowest: compound 1; then compound 2; then compounds 3 and 4 (each within the scatter of the next).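

In this assay, the step that removes the carbonyl from the group on the amine nitrogen in a ring is a 1.6-fold higher number from compound 3 to compound 4 (0.21 log units; within the scatter) and so does not separate the two compounds. At this position, (1-(trifluoromethyl)cyclopropyl)methyl therefore reads the same as the carbonyl-bearing group of compound 3, which shows that a carbonyl at this nitrogen is not needed for a number in this range. Among these compounds, the carbamates stay apart from it, with a 4.6-fold higher number from compound 2 to compound 4 (0.66 log units; beyond the scatter) for isopropoxycarbonyl and an 11-fold higher number from compound 1 to compound 4 (1.03 log units; beyond the scatter) for tert-butoxycarbonyl, the latter the only large step in the set, although compound 3 goes against any reading that the carbonyl alone sets the number, and nothing supplied explains these differences.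

On these data alone, it remains open whether the trifluoromethyl or the cyclopropyl ring of the entering group matters, which a plain cyclopropylmethyl or a 2,2,2-trifluoroethyl group on the same nitrogen would help to separate. Also open, as far as these compounds go, is whether a urea or a benzyl group at this nitrogen would read with compound 1 or with compound 4.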